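An Iodo Group in Place of Isopropyl: An Expected Value

A few compounds are considered here, and "the series" means these few. Any claim that something is new, unique, unknown or untested is made for them only; others in the source may bear on it.

Compound 1, `COc1cccc(-n2cc(COc3cccc(NC(=O)Nc4ccc(Cl)c(C(F)(F)F)c4)c3)nn2)c1`: 1310 nM
Compound 2, `CCc1cccc(-n2cc(COc3cccc(NC(=O)Nc4ccc(Cl)c(C(F)(F)F)c4)c3)nn2)c1`: 37900 nM
Compound 3, `CC(C)c1cccc(-n2cc(COc3cccc(NC(=O)Nc4ccc(Cl)c(C(F)(F)F)c4)c3)nn2)c1`: 3250 nM

In a functional assay on HepG2 cells (Homo sapiens) for inhibition, read by MTT assay, with a stated time of 72 h (a lower number here means a stronger inhibitor, a higher number a weaker inhibitor), compound 3 sits second highest of the three numbers. Its nearest neighbour is compound 1, reached by the step of a 2.5-fold higher number from compound 1 to compound 3 (0.39 log units; beyond the scatter), and its furthest is compound 2, as the step of a 12-fold lower number from compound 2 to compound 3 (1.07 log units; beyond the scatter) shows. Compound 4, `O=C(Nc1cccc(OCc2cn(-c3cccc(I)c3)nn2)c1)Nc1ccc(Cl)c(C(F)(F)F)c1`, differs from compound 3 in one place: iodo in place of isopropyl on an aromatic carbon. Within the data shown here, no measured step involves an iodo group on that aromatic carbon. Among the measured compounds shown here, the steps of a 29-fold higher number from compound 1 to compound 2 (1.46 log units; beyond the scatter) and a 12-fold lower number from compound 2 to compound 3 (1.07 log units; beyond the scatter) show only that small changes at this position have moved the numbers widely in both directions, so neither bears directly on the new change, and the direction of this step cannot be read from them. Compound 4 is therefore expected close to compound 3, with the step of a 1.1-fold lower number from compound 3 to compound 4 (0.03 log units; within the scatter) lying within the scatter, while either direction remains possible and the range is kept wide. The estimate for compound 4 is 3000 nM, between 700 nM and 15000 nM.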

Compound 4, half-maximal inhibitory concentration: 4780 nM
The estimate for compound 4 lay 1.6-fold (0.20 log units) below the measured number, within the range that was stated.
By their numbers in this assay, from the lowest: compound 1; then compounds 3 and 4 (each within the scatter of the next); then compound 2.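

In this assay the iodo group gives a 1.5-fold higher number from compound 3 to compound 4 (0.17 log units; within the scatter), so at this aromatic carbon iodo and isopropyl cannot be told apart, and a single iodine atom serves as well as the branched group in this read-out. Iodo also keeps the distance from the other two groups, with a 7.9-fold lower number from compound 2 to compound 4 (0.90 log units; beyond the scatter) and with a 3.6-fold higher number from compound 1 to compound 4 (0.56 log units; beyond the scatter), which leaves compound 2 with the ethyl group as the one high number among the four and compound 1 with the methoxy group as the one low number. Nothing available explains why these groups fall as they do.

What the compounds shown leave open is how an amine, a carboxylic acid or a nitrile would read at this same carbon. Also open, as far as these compounds go, is whether the ethyl result would recur in a longer chain such as propyl.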